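This account rests on a few compounds, and the source may have more. Where it says the series, first, only, none or still open, it means among the compounds named here.

Two compounds of this series have been run in a functional assay on A549 cells (Homo sapiens) for inhibition, read by MTT assay, with a stated time of 72 h; a higher number here means a weaker inhibitor, a lower number a stronger inhibitor. Compound 1 `O=C1Nc2ccc(Br)cc2/C1=N/NC(=S)N1CCN(c2ccccc2)CC1` gives 12300 nM in this assay. Compound 2 `Cc1ccc(N2CCN(C(=S)N/N=C3\C(=O)Nc4ccc(Cl)cc43)CC2)c(C)c1` gives 3590 nM in this assay, the lowest of the two numbers, with compound 1 sitting a gap beyond the scatter above it. For the measured compounds named here, compound 1 and compound 2 differ in more than one place, so no single step between measured compounds is available; the two values show only that compound 2 is the stronger of the pair.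

Compound 3 `O=C1Nc2ccc(Cl)cc2/C1=N/NC(=S)N1CCN(c2ccccc2[N+](=O)[O-])CC1` has not yet been measured. It is built from compound 2 by one change: 2-nitrophenyl in place of 2,4-dimethylphenyl on an amine nitrogen in a ring. Going by the values given here, with no measured step at the amine nitrogen in a ring to draw on, the size of the step from compound 2 to compound 3 in this assay rests on compound 2 alone. A small step toward a higher number is expected, a 1.5-fold higher number from compound 2 to compound 3 (0.19 log units; within the scatter), likely at or just beyond the edge of the scatter. Compound 3 is therefore expected to give about 5500 nM in this assay, within a range of 1800 nM to 17000 nM.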

Compound 3, half-maximal inhibitory concentration: 5580 nM
Compound 3: the middle estimate sits 1.0-fold (0.01 log units) below what was measured, within the range that was stated.
By their numbers in this assay, from the lowest: compounds 2 and 3 (each within the scatter of the next); then compound 1.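

In this assay, for the compounds shown here, putting 2-nitrophenyl in place of 2,4-dimethylphenyl on the amine nitrogen in a ring gives a 1.6-fold higher number from compound 2 to compound 3 (0.19 log units; within the scatter) and is the first step that can be read at this position. Two differently substituted phenyl groups therefore give values within the scatter of each other at this site, even though the change swaps a carbon-only pair of methyl groups for a nitro group that brings in hydrogen-bond acceptors. No measurement on hand explains the size of this step.

Compound 1, at 12300 nM, differs from compound 2 and from compound 3 in more than one place, so its steps to them cannot be read, and the separate contributions of the halogen on the shared core and of the substituents on the phenyl group remain unresolved. From the compounds shown here alone, it also remains open whether this insensitivity extends beyond substituted phenyl groups on the ring nitrogen, for example to a benzyl group, a pyridine ring or a simple alkyl chain, or to a methoxy group on the phenyl ring.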